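Aryl swap on the enone of the sulfonylurea series

A few compounds are considered here, and "the series" means these few. Any claim that something is new, unique, unknown or untested is made for them only; others in the source may bear on it.

Measured compounds:
- compound 1 `COc1ccc(/C=C/C(=O)c2ccccc2NC(=O)NS(=O)(=O)c2ccc(C)cc2)cc1`: 28.1 ug/mL
- compound 2 `Cc1ccc(S(=O)(=O)NC(=O)Nc2ccccc2C(=O)/C=C/c2ccccc2[N+](=O)[O-])cc1`: 40.1 ug/mL

In an ADME assay on the whole organism for cytotoxicity, with Artemia salina as the target, with a stated time of 24 h (on this read-out higher numbers stand for an effect only at larger amounts of compound and lower numbers for an effect already at smaller amounts), compound 2 gives 40.1 ug/mL, the highest of the two numbers recorded; its nearest neighbour is compound 1, which gives 28.1 ug/mL, and the step from compound 1 to compound 2 is a 1.4-fold higher number from compound 1 to compound 2 (0.15 log units; within the scatter).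

Compound 3 `Cc1ccc(S(=O)(=O)NC(=O)Nc2ccccc2C(=O)/C=C/c2cccc(F)c2)cc1` has not yet been measured in this assay. It differs from compound 2 in one place: 3-fluorophenyl in place of 2-nitrophenyl on a double-bonded chain carbon bound to a double-bonded chain carbon.

Among the compounds with values here, only one measured step bears on this change, and it concerns the same position: a 1.4-fold higher number from compound 1 to compound 2 (0.15 log units; within the scatter), a swap of one aryl group for another on the double-bonded chain carbon that left the number within the scatter. Within the data shown here, no measured pair shows the 3-fluorophenyl itself, so the expectation rests on that single step alone. A further aryl swap at the same place is therefore expected to give no step beyond the scatter, in either direction, and the expected step from compound 2 to compound 3 is a 1.1-fold lower number from compound 2 to compound 3 (0.06 log units; within the scatter).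

Compound 3 is accordingly estimated at 35 ug/mL in this assay, with a range from 15 ug/mL to 80 ug/mL.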

Compound 3, concentration for half-maximal effect: 4.13 ug/mL
Estimate against measurement, compound 3: 8.5-fold (0.93 log units) above; the measured number lies below the stated range.
By their numbers in this assay, from the lowest: compound 3; then compounds 1 and 2 (each within the scatter of the next).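

Working notes on the aryl group at this position, on a double-bonded chain carbon bound to a double-bonded chain carbon. In this assay, the earlier swap stayed within the scatter (a 1.4-fold higher number from compound 1 to compound 2 (0.15 log units; within the scatter)), so the two aryl groups first compared gave no sign that this position responds to the aryl group. The 3-fluorophenyl group changes that reading, with steps beyond the scatter against both earlier groups (a 9.7-fold lower number from compound 2 to compound 3 (0.99 log units; beyond the scatter); a 6.8-fold lower number from compound 1 to compound 3 (0.83 log units; beyond the scatter)), and it thus separates from 2-nitrophenyl and 4-methoxyphenyl, which remain within the scatter of each other. No supporting measurement is available to account for this separation.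

The compounds shown do not separate the identity of the substituent from its place on the ring, since 3-fluorophenyl differs from each of the other two groups in both respects at once. As far as these compounds go, it also remains open whether the lower number belongs to fluorine specifically or would also appear with an unsubstituted phenyl or with a phenyl carrying chlorine or an amine.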